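Replacing a fluorophenyl amine with a hydroxyphenyl amine

The compounds below may be only part of what the source reports. "The series", "measured", "known", "first", "only" and "open" are said of these compounds alone.

Working notes on a small quinazoline-free set of anilines sharing one core. Compound 2 `Fc1cccc(Nc2nc(-c3cccc(F)c3)nc3ccc(F)cc23)c1` was run in a functional assay on COLO 205 cells (Homo sapiens) for cytotoxicity, read by MTT assay, with a stated time of 48 h; a lower number here means a stronger inhibitor, a higher number a weaker inhibitor. In this assay compound 2 returns only a limit, > 50000 nM. Compound 1 `Fc1cccc(-c2nc(Nc3ccccc3)c3ccccc3n2)c1` carries the same core without the added fluorine. In this assay compound 1 also returns only a limit, > 50000 nM. Compound 3 `Fc1cccc(-c2nc(Nc3ccccc3F)c3cc(F)ccc3n2)c1` differs from compound 2 in a single place. In this assay compound 3 again returns only a limit, > 50000 nM. For the measured compounds named here, the one measured step, a step that the two limits leave unreadable from compound 2 to compound 3, is therefore not readable in size or direction. Where compound 2 stands can be said only this far: it sits with the other two at the limit of > 50000 nM in this assay, at which 3 of the 3 values shown sit, and no number separates it from compound 1 or compound 3.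

Compound 4 `Oc1ccccc1Nc1nc(-c2cccc(F)c2)nc2ccc(F)cc12` differs from compound 2 by 2-hydroxyphenyl in place of 3-fluorophenyl on a nitrogen on an aromatic ring. The step that bears on this nitrogen, a step that the two limits leave unreadable from compound 2 to compound 3, gives no size, so the expectation rests on the limit of > 50000 nM in this assay, at which 3 of the 3 values shown sit, alone. The expected step in this assay is a step that the limit leaves unreadable from compound 2 to compound 4, nothing beyond the scatter that can be asserted. Compound 4 is estimated to give about 60000 nM in this assay. The range expected for compound 4 runs from 25000 nM to 200000 nM, with a limit the most likely outcome.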

Compound 4, half-maximal inhibitory concentration: > 50000 nM
Compound 4: a limit, no number (the forecaster's own chance of this, stated with the estimate: 80%); the middle value is on the limit's open side.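

In this assay compound 4 returns only a limit, > 50000 nM. The steps to compound 4 from compound 2 and from compound 3 cannot be read, as every value shown is a limit: the limit of > 50000 nM in this assay, at which 4 of the 4 values shown sit.

The compounds shown leave open whether any group on this nitrogen of the shared core would give a number rather than a limit in this assay.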